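Phenyl to Cyclopropyl on a Cyclic Amide Nitrogen

The source may report more compounds than this note shows. Statements on the series, on what has been measured and on what is new or still open speak of the compounds shown alone.

Compound 1 `O=C1COc2ccc(-c3cccc(NS(=O)(=O)c4ccc(F)cc4)c3)cc2N1c1ccccc1` carries a phenyl on an amide-type nitrogen in a ring. In a functional assay on HCT-116 cells (Homo sapiens) for antiproliferative activity, read by MTT assay, with a stated time of 72 h (a higher number here means a weaker inhibitor, a lower number a stronger inhibitor), compound 1 gives only a limit, > 40000 nM, and no number. Compound 3 `O=C1COc2ccc(-c3cccc(NS(=O)(=O)c4ccc(F)cc4)c3)cc2N1C1CC1` differs from it by cyclopropyl in place of phenyl on an amide-type nitrogen in a ring. In this assay compound 3 likewise gives a limit, > 40000 nM. The step that the two limits leave unreadable from compound 1 to compound 3 therefore cannot be sized, since both values sit at the limit of > 40000 nM in this assay, at which 2 of the 3 values shown sit.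

Compound 2 `O=C1COc2ccc(-c3cnc(Cl)c(NS(=O)(=O)c4ccc(F)cc4)c3)cc2N1c1ccccc1` has a different core; the difference between the two cores is not broken down here. In this assay, within the data shown here, compound 2 gives 39800 nM, the only real number among the three measured compounds.

Compound 4 `O=C1COc2ccc(-c3cnc(Cl)c(NS(=O)(=O)c4ccc(F)cc4)c3)cc2N1C1CC1` stands to compound 2 as compound 3 stands to compound 1: the change is cyclopropyl in place of phenyl on an amide-type nitrogen in a ring, made at the same place in both pairs. Because the earlier step that the two limits leave unreadable from compound 1 to compound 3 is unreadable from two limits, it offers no direction for the new pair, and compound 2 itself lies close to the limit of > 40000 nM in this assay, at which 2 of the 3 values shown sit. The step from compound 2 to compound 4 in this assay is expected to be small, about a 1.0-fold higher number from compound 2 to compound 4 (0.00 log units; within the scatter). Compound 4 is thus estimated at 40000 nM in this assay, within a range from 15000 nM to 90000 nM, with a fair chance that only a limit is returned.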

Compound 4, half-maximal inhibitory concentration: 12400 nM
Estimate against measurement, compound 4: 3.2-fold (0.51 log units) above, outside the stated range (below it).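

On the core of compound 2, cyclopropyl in place of phenyl on the amide-type nitrogen in a ring gives, in this assay, a 3.2-fold lower number from compound 2 to compound 4 (0.51 log units; beyond the scatter), so the change has one readable effect in this series, and compound 4 stands at 12400 nM. The same change on the core of compound 1 cannot be read, because compound 1 and compound 3 each return only a limit and no number: the limit of > 40000 nM in this assay, at which 2 of the 4 values shown sit. This means that the series does not show that the change carries from one core to another, since a single readable pair gives the size and direction of the step on one core only, and nothing from the other pair either supports or contradicts it.

The compounds shown leave open whether the lower number belongs to cyclopropyl in particular or would also appear with another group on that nitrogen, such as methyl, a longer chain such as n-butyl, or a chain ending in an amine. Going by these compounds, it also remains open whether any such group would bring the core of compound 1 to a readable number in this assay, or whether a readable step is confined to the core of compound 2.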